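The compounds below may be only part of what the source reports. "The series", "measured", "known", "first", "only" and "open" are said of these compounds alone.

Measured compounds:
Compound 2 `CC(C)c1cccc(C(C)C)c1NC(=O)NCC1(c2cccs2)CCCC1`: 12 nM
Compound 1 `CC(C)c1cccc(C(C)C)c1NC(=O)NCC1(c2cccnc2)CCCC1`: 97 nM

Among the compounds with values here, in an assay on microsomes from intestine for inhibition of acyl-CoA:cholesterol acyltransferase (Oryctolagus cuniculus) (a higher number here means a weaker inhibitor, a lower number a stronger inhibitor), compound 2 gives 12 nM, the lowest of the two numbers measured so far; compound 1 gives 97 nM. Within this pair compound 2 stands apart from compound 1 by an 8.1-fold lower number from compound 1 to compound 2 (0.91 log units; beyond the scatter), so the swap of the aromatic ring on the saturated carbon made a clear difference once.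

Compound 3 `CC(C)c1cccc(C(C)C)c1NC(=O)NCC1(c2ccsc2)CCCC1` has not been measured in this assay. Compared with compound 2, the change is thiophen-3-yl in place of thiophen-2-yl on a saturated ring carbon. Within the data shown here, no measured step mirrors this change: the one step recorded, an 8.1-fold lower number from compound 1 to compound 2 (0.91 log units; beyond the scatter), exchanges one aromatic ring for another of a different kind, whereas here the same ring is kept and only its point of attachment moves. That step shows the ring on this carbon matters, but gives no direction for a move within the thiophene itself. Compound 3 is therefore estimated to stay close to compound 2, at about 20 nM with a likely range from 6 nM to 60 nM. The expected step is a 1.7-fold higher number from compound 2 to compound 3 (0.22 log units; within the scatter), which is not beyond the usual scatter.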

Compound 3, half-maximal inhibitory concentration: 18 nM
Compound 3: the middle estimate sits 1.1-fold (0.05 log units) above what was measured, and the stated range covers the measured number.
By their numbers in this assay, from the lowest: compounds 2 and 3 (each within the scatter of the next); then compound 1.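

In this assay, moving the attachment point of the thiophene on the saturated ring carbon, with thiophen-3-yl in place of thiophen-2-yl, gives a 1.5-fold higher number from compound 2 to compound 3 (0.18 log units; within the scatter) and so leaves the two attachments indistinguishable in this pair. Replacing the pyridin-3-yl ring of compound 1 with thiophen-3-yl gives a 5.4-fold lower number from compound 1 to compound 3 (0.73 log units; beyond the scatter) and thus runs in the same direction as the earlier step to compound 2, which shows that the lower number found there is not confined to the thiophen-2-yl attachment. Nothing available offers an explanation for either result, and the three compounds alone cannot separate what the sulfur ring contributes from what the missing ring nitrogen contributes.

As far as these compounds go, whether a plain phenyl ring or a furan-2-yl ring on the same carbon would group with the two thiophenes or with compound 1 remains open, as does the effect of a methyl group on the thiophene. Within the data shown here, also open is what a cyclohexane ring would do in place of the five-membered ring of carbon only that carries these groups.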